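Compound 3 to compound 4: leaving the piperidin-1-yl group

This account rests on a few compounds, and the source may have more. Where it says the series, first, only, none or still open, it means among the compounds named here.

In a functional assay on A549 cells (Homo sapiens) for cytotoxicity, read by MTT assay, with stated times of 48 h and 4 h (a higher number here means a weaker inhibitor, a lower number a stronger inhibitor), compound 1 `COc1ccc(/C=C/c2nc(NCCN3CCCCC3)c3ccccc3n2)cc1OC` stands at 82700 nM and compound 2 `COc1ccc(/C=C/c2nc(NCCN(C)C)c3cc(Cl)ccc3n2)cc1OC` at 21300 nM on the same scale. Compound 3 `COc1ccc(/C=C/c2nc(NCCN3CCCCC3)c3cc(Cl)ccc3n2)cc1OC` shows > 100000 nM as its reading, which is a limit of the assay and not a number.

Compound 4 `COc1ccc(/C=C/c2nc(NCCCCN)c3cc(Cl)ccc3n2)cc1OC` carries 2-aminoethyl in place of piperidin-1-yl on a saturated chain carbon, two bonds along the chain from a nitrogen on an aromatic ring. The same difference, cut further out, reads (2-(piperidin-1-yl)ethyl)amino to (4-aminobutyl)amino.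

The step that bears most directly is an at least 4.6-fold higher number from compound 2 to compound 3 (0.67 log units; beyond the scatter) with piperidin-1-yl in place of dimethylamino at that same place. The step of an at least 1.2-fold higher number from compound 1 to compound 3 (0.08 log units; that floor lies within the scatter) concerns chloro in place of hydrogen and gives no size for this change. Within the data shown here, no measured compound carries 2-aminoethyl at this place. Without piperidin-1-yl, compound 2 at 21300 nM sits lower, so a lower number is expected in this assay for the change at hand.

The expected step is an at least 3.3-fold lower number from compound 3 to compound 4 (0.52 log units; beyond the scatter) in size, an estimate that rests on a limit rather than a number. For compound 4 the estimate is 30000 nM with an expected range from 9000 nM to 100000 nM in this read-out.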

Compound 4, half-maximal inhibitory concentration: 50500 nM
Beside the measured number, compound 4's estimate is 1.7-fold (0.23 log units) below it; the range from low to high includes it.
By their numbers in this assay, from the lowest: compound 2; then compounds 4 and 1 (each within the scatter of the next). At a limit, above all of these: compound 3.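

In this assay, the reading for compound 3 is a limit and not a number: the limit of > 100000 nM in this assay, at which 1 of the 4 values shown sits.

Setting 2-aminoethyl in place of piperidin-1-yl on the saturated chain carbon gives an at least 1.9-fold lower number from compound 3 to compound 4 (0.29 log units; that floor lies within the scatter) and thus only a floor on the size of this change. Against dimethylamino at the same place, the new group gives a 2.4-fold higher number from compound 2 to compound 4 (0.37 log units; beyond the scatter) and shows what the earlier compounds could not: among the chloro compounds, a side chain with no ring does not by that feature alone match compound 2.

Compound 4 differs from compound 2 in both chain length and the substitution on the end nitrogen, so the two contributions stay unseparated; a 4-(dimethylamino)butyl group at this place would bear on that question. Whether the chloro group matters with a 4-aminobutyl chain also stays open, since the compounds shown include no partner of compound 4 with hydrogen in place of chloro.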